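Adding three methoxy groups to a chalcone-imidazolone series

This account rests on a few compounds, and the source may have more. Where it says the series, first, only, none or still open, it means among the compounds named here.

Three compounds share one core and were tested in a functional assay on T47D cells (Homo sapiens) for inhibition; a lower number here means a stronger inhibitor of growth, a higher number a weaker inhibitor of growth. Compound 1 `COc1cc(/C=C/C(=O)c2cccc(-n3cc(-c4ccc(Cl)cc4)[nH]c3=O)c2)ccc1O` gives 3090 nM. Compound 2 `COc1cc(/C=C/C(=O)c2cccc(-n3cc(-c4ccccc4)[nH]c3=O)c2)cc(OC)c1OC` gives 2190 nM. Compound 3 `O=C(/C=C/c1cccc(O)c1)c1cccc(-n2cc(-c3ccccc3)[nH]c2=O)c1` gives 4240 nM. Compound 2 sits at the low end of these three numbers, yet all three lie within the usual scatter of one another, so no real difference among them can be claimed.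

Compound 4 `COc1cc(/C=C/C(=O)c2cccc(-n3cc(-c4cc(OC)c(OC)c(OC)c4)[nH]c3=O)c2)cc(OC)c1OC` is not yet measured. It differs from compound 2 in one place: 3,4,5-trimethoxyphenyl in place of phenyl on an aromatic carbon. Going by the values given here, no measured pair in this set isolates such a change, so nothing known points to a direction; the step is expected to stay within the scatter, a 1.1-fold lower number from compound 2 to compound 4 (0.04 log units; within the scatter). Compound 4 is therefore estimated to give 2000 nM in this assay, between 700 nM and 6000 nM.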

Compound 4, concentration for 50% growth inhibition: 3080 nM
Estimate against measurement, compound 4: 1.5-fold (0.19 log units) below, within the range that was stated.
By their numbers in this assay, from the lowest: compounds 2, 4, 1 and 3 (each within the scatter of the next).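

Going by these compounds alone, until now no pair of compounds isolated this position on the five-membered ring. In this assay, 3,4,5-trimethoxyphenyl in place of phenyl gives a 1.4-fold higher number from compound 2 to compound 4 (0.15 log units; within the scatter) and so shows that this larger group, with its three methoxy groups, leaves the result within the scatter. Nothing available explains this outcome. Still open, on these data alone, is whether an amine or a carboxylic acid on this aromatic ring, rather than methoxy groups, would move the number beyond the scatter.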